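Chloro on the anilino ring: notes on compound 3

The source may report more compounds than this note shows. Statements on the series, on what has been measured and on what is new or still open speak of the compounds shown alone.

Values in a functional assay on A2780 cells (Homo sapiens) for antiproliferative activity; on this read-out higher numbers stand for weaker inhibition and lower numbers for stronger inhibition:
- compound 1 `NC1CCN(Cc2ccn3ncnc(Nc4ccccc4)c23)CC1`: 3700 nM
- compound 2 `Cc1ccccc1Nc1ncnn2ccc(CN3CCC(N)CC3)c12`: > 5000 nM, a limit
- compound 3 `NC1CCN(Cc2ccn3ncnc(Nc4cccc(Cl)c4)c23)CC1`: not yet measured

In this assay, within the data shown here, compound 1 gives 3700 nM, the only actual number so far. The one other result is a limit and not a number, and it belongs to compound 2.

Compound 3 keeps the core and side chain of compound 1 and has chloro in place of hydrogen on an aromatic carbon, meta to a large group (chloro in place of hydrogen on an aromatic carbon). The same difference reads phenyl to 3-chlorophenyl.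

Among the measured compounds shown here, one measured step bears on this change, methyl in place of hydrogen on an aromatic carbon, and it shows an at least 1.3-fold higher number from compound 1 to compound 2 (0.13 log units; that floor lies within the scatter). That step involves a different group and its floor stays within the scatter, so it gives neither a firm size nor a firm direction. No step beyond the scatter is therefore expected in this assay, though the uncertainty is wide in both directions.

The step expected from this estimate is a 1.5-fold lower number from compound 1 to compound 3 (0.17 log units; within the scatter). For compound 3 the estimated value is 2500 nM, with an expected range of 600 nM to 6000 nM.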

Compound 3, half-maximal inhibitory concentration: > 5000 nM
Compound 3 gave a limit, no number; the forecaster's own chance of this, stated with the estimate: 20%; middle value at least 2.0-fold (0.30 log units) away from the limit.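

In this assay compound 3 gives > 5000 nM, which is a limit and not a number. Replacing the plain phenyl with 3-chlorophenyl gives an at least 1.3-fold higher number from compound 1 to compound 3 (0.13 log units; that floor lies within the scatter); this position therefore shows no sign of a lower number with chloro, although a real rise remains unconfirmed. Compound 1, with the plain phenyl, is now the only one of the three compounds with an actual number, while the two compounds with a substituent on this ring, 2-methylphenyl in compound 2 and 3-chlorophenyl in compound 3, both end at the same limit: the limit of > 5000 nM in this assay, at which 2 of the 3 values shown sit.

Going by these compounds, the two limits leave the step between compound 2 and compound 3 unreadable, and how far either compound lies past the limit stays unknown. Still open, on these data alone, is whether the same outcome holds for another group at this position, such as fluoro, methoxy or an amine, or for chloro elsewhere on the ring, and whether any substituent on this ring can give a lower number than compound 1.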